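From nitro to fluoro on the phenoxy end

The source may report more compounds than this note shows. Statements on the series, on what has been measured and on what is new or still open speak of the compounds shown alone.

Of the compounds shown here, three sharing one core have been measured in a functional assay on Jurkat cells (Homo sapiens); a lower number here means a stronger inhibitor, a higher number a weaker inhibitor. Compound 1 (`CC(C)[C@H](NC(=O)COc1cccc2ccccc12)C(=O)N[C@@H](CC(=O)O)C(=O)COc1cccc(C(F)(F)F)c1`) gives > 100000 nM, which is a limit of the assay and not a number. Compound 3 (`CC(C)[C@H](NC(=O)COc1cccc2ccccc12)C(=O)N[C@@H](CC(=O)O)C(=O)COc1ccc([N+](=O)[O-])cc1`) gives > 100000 nM, which is likewise a limit. Compound 3 therefore sits at the limit of > 100000 nM in this assay, at which 2 of the 3 values shown sit. Within the data shown here, compound 2 (`CC(C)[C@H](NC(=O)COc1cccc2ccccc12)C(=O)N[C@@H](CC(=O)O)C(=O)COc1ccc(Oc2ccccc2)cc1`) gives 12700 nM, the only true number so far.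

Compound 4 (`CC(C)[C@H](NC(=O)COc1cccc2ccccc12)C(=O)N[C@@H](CC(=O)O)C(=O)COc1ccc(F)cc1`) has fluoro in place of nitro on an aromatic carbon, para to a large group: fluoro in place of nitro on an aromatic carbon.

The measured step that bears most directly on this change is an at least 7.8-fold higher number from compound 2 to compound 3 (0.89 log units; beyond the scatter), where nitro replaces phenoxy on the same aromatic carbon. The other step, a step that the two limits leave unreadable from compound 1 to compound 3, gives no usable size. Among the measured compounds shown here, compound 4 lacks the phenoxy group of compound 2, the only compound with a true number at 12700 nM, so no clear gain is expected in this assay. The expected step is an at least 1.1-fold lower number from compound 3 to compound 4 (0.04 log units; that floor lies within the scatter), which would not be a change beyond the scatter, and a reading at the limit again is quite possible. For compound 4 the estimated value is 90000 nM, with an expected range from 25000 nM to 300000 nM.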

Compound 4, half-maximal inhibitory concentration: > 100000 nM
Compound 4: only a limit was reported (the forecaster's own chance of this, stated with the estimate: 65%); middle value at least 1.1-fold (0.04 log units) away from the limit.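

In this assay compound 4 gives > 100000 nM, which is a limit of the assay and not a number. The steps from compound 3 and from compound 1 to compound 4 cannot be read, since both ends of each are limits, so nothing can be said about how fluoro and nitro rank at this position. The one readable step is an at least 7.8-fold higher number from compound 2 to compound 4 (0.89 log units; beyond the scatter), with fluoro in place of phenoxy; a replacement of a single heavy atom thus joins the three-heavy-atom nitro group in giving no true number on this aromatic carbon, phenoxy remains the only group there with one, and the series now stands as follows: the limit of > 100000 nM in this assay, at which 3 of the 4 values shown sit.

The compounds shown leave open whether the true number of compound 2 depends on the phenoxy group itself, or whether another group in the same place, such as benzyloxy or an amine, would also give one. They also do not tell how far compound 1, compound 3 and compound 4 lie beyond the limit, so no order among these three can be given.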